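Removing the hydroxy group from compound 1

The compounds below may be only part of what the source reports. "The series", "measured", "known", "first", "only" and "open" are said of these compounds alone.

Compound 1 (`Cc1noc(NS(=O)(=O)c2ccc(NC(=O)c3cc4ccc(O)cc4oc3=O)cc2)c1C`): 38800 nM
Compound 2 (`CCOc1ccc2nc(Cl)c(/C=N/NC(=O)c3cc4cc([N+](=O)[O-])ccc4oc3=O)cc2c1`): 18100 nM

Both values come from a functional assay on HepG2 cells (Homo sapiens) for antiproliferative activity, read by fluorescence and resazurin assay, with a stated time of 48 h; a higher number here means a weaker inhibitor, a lower number a stronger inhibitor. Compound 1, at 38800 nM, holds the higher of the two numbers, and compound 2, at 18100 nM, lies lower by a gap just beyond the usual scatter.

The next compound to be measured is compound 3 (`Cc1noc(NS(=O)(=O)c2ccc(NC(=O)c3cc4ccccc4oc3=O)cc2)c1C`). It differs from compound 1 in one place: hydrogen in place of hydroxy on an aromatic carbon. In words, hydrogen stands in place of hydroxy on an aromatic carbon.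

Among the measured compounds shown here, the measured pair offers no single-change step to go by, so the expectation is weakly grounded. In this assay, no step beyond the scatter is expected, and no direction is favoured with confidence. The expected step is a 1.2-fold lower number from compound 1 to compound 3 (0.07 log units; within the scatter). Compound 3 is estimated at 33000 nM, with an expected range from 14000 nM to 75000 nM.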

Compound 3, half-maximal inhibitory concentration: 24000 nM
Compound 3: middle estimate off by 1.4-fold (0.14 log units), on the high side, within the range that was stated.
By their numbers in this assay, from the lowest: compounds 2, 3 and 1 (each within the scatter of the next, the first and the last beyond it).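

Among the compounds shown here, this is the first single-change step: in this assay, putting hydrogen in place of hydroxy on an aromatic carbon gives a 1.6-fold lower number from compound 1 to compound 3 (0.21 log units; within the scatter), a step that stays within the usual scatter. At this position, losing the hydroxy group, with its hydrogen-bond donor and acceptor, therefore leaves the antiproliferative read-out on HepG2 cells without a change that can be told from noise, so the hydroxy group is not shown to be needed for the activity seen in compound 1. Nothing measured here accounts for this step or ties it to any property of the group.

From the compounds shown here alone, whether a different group on the same aromatic carbon, such as methoxy, an amine or a carboxylic acid, would move the number beyond the scatter remains open. Compound 2 differs from compound 3 in more than one place, so it does not help to settle this.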